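Fluoro for bromo on a shared aryl-triazole scaffold

The source may report more compounds than this note shows. Statements on the series, on what has been measured and on what is new or still open speak of the compounds shown alone.

Of the compounds shown here, three of one series have been measured in a functional assay on B16-F10 cells (Mus musculus) for antiproliferative activity, read by MTT assay, with a stated time of 72 h; on this read-out higher numbers stand for weaker inhibition and lower numbers for stronger inhibition. Compound 1 `CC(=O)Oc1ccc(/C=C/C(=O)OCCSc2nc(-c3ccc(S(C)(=O)=O)cc3)n(-c3ccc(C(F)(F)F)cc3)n2)cc1OC(C)=O` gives 11500 nM, compound 2 `CC(=O)Oc1ccc(/C=C/C(=O)NCCSc2nc(-c3ccc(S(C)(=O)=O)cc3)n(-c3ccc(F)cc3)n2)cc1OC(C)=O` gives 14600 nM, and compound 3 `CC(=O)Oc1ccc(/C=C/C(=O)NCCCSc2nc(-c3ccc(S(C)(=O)=O)cc3)n(-c3ccc(Br)cc3)n2)cc1OC(C)=O` gives 16400 nM. Compound 3 holds the highest of the three numbers, yet the gaps to compound 2 and to compound 1 both lie within the usual scatter, so no order among the three can be claimed. Compound 4 `CC(=O)Oc1ccc(/C=C/C(=O)NCCCSc2nc(-c3ccc(S(C)(=O)=O)cc3)n(-c3ccc(F)cc3)n2)cc1OC(C)=O` is not yet measured; it differs from compound 3 by fluoro in place of bromo on an aromatic carbon. Compound 2 carries the same fluoro group, with a different linker, and its value sits close to that of compound 3. Compound 4 is therefore expected to show no step beyond the scatter, a 1.1-fold lower number from compound 3 to compound 4 (0.04 log units; within the scatter), with an estimated 15000 nM in this assay, ranging from 7000 nM to 32000 nM.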

Compound 4, half-maximal inhibitory concentration: 15200 nM
Compound 4: middle estimate off by 1.0-fold (0.01 log units), on the low side, and the stated range covers the measured number.
By their numbers in this assay, from the lowest: compounds 1, 2, 4 and 3 (each within the scatter of the next).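

For the compounds shown here, the earlier compounds differed in more than one place, so this is the first comparison that isolates the halogen on this aromatic carbon. In this assay, fluoro in place of bromo gives a 1.1-fold lower number from compound 3 to compound 4 (0.03 log units; within the scatter), so the two halogens cannot be told apart here, at least with this linker and the rest of the scaffold held constant. No measured evidence bears on this result.

As far as these compounds go, it remains open whether an amine or a carboxylic acid on this aromatic carbon would move the number beyond the scatter. From the compounds shown here alone, the effect of a longer chain in the linker also remains open.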